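Aryl Swap on a Pyrazole Core: Expected Antiproliferative Shift

The compounds below may be only part of what the source reports. "The series", "measured", "known", "first", "only" and "open" are said of these compounds alone.

Measured compounds:
compound 1 `Cc1nn(-c2nc(-c3ccc(Cl)c(Cl)c3)c(SC(C)C)s2)c(C(=O)O)c1-c1cncnc1`, 22000 nM
compound 2 `COc1ccc(-c2c(C)nn(-c3nc(-c4ccc(Cl)c(Cl)c4)c(SC(C)C)s3)c2C(=O)O)cc1`, 2100 nM
compound 3 `Cc1nn(-c2nc(-c3ccc(Cl)c(Cl)c3)c(SC(C)C)s2)c(C(=O)O)c1-c1cncc(C#N)c1`, 20000 nM

In a functional assay on BJAB cells (Homo sapiens) for antiproliferative activity, with a stated time of 4 days (on this read-out lower numbers stand for an effect already at smaller amounts and higher numbers for an effect only at larger amounts of compound), compound 3 stands second highest of the three, with compound 1 nearest, a 1.1-fold lower number from compound 1 to compound 3 (0.04 log units; within the scatter), and compound 2 furthest, a 9.5-fold higher number from compound 2 to compound 3 (0.98 log units; beyond the scatter). Compound 4 `Cc1cccc(-c2c(C)nn(-c3nc(-c4ccc(Cl)c(Cl)c4)c(SC(C)C)s3)c2C(=O)O)c1` differs from compound 3 in one place: 3-methylphenyl in place of 5-cyanopyridin-3-yl on an aromatic carbon. Going by the values given here, the step that bears on this is the one between compound 2 and compound 3, where a carbon-only aromatic ring gave the lower number, a 9.5-fold higher number from compound 2 to compound 3 (0.98 log units; beyond the scatter); the step of a 1.1-fold lower number from compound 1 to compound 3 (0.04 log units; within the scatter) shows two heteroaromatic rings behaving alike. Since compound 4 again carries a carbon-only ring, a move toward lower numbers is expected, roughly reversing that step, a 6.7-fold lower number from compound 3 to compound 4 (0.82 log units; beyond the scatter). The estimate for compound 4 in this assay is 3000 nM, between 1000 nM and 9000 nM.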

Compound 4, half-maximal effective concentration: 17000 nM
Compound 4: middle estimate off by 5.7-fold (0.75 log units), on the low side; the measured number lies above the stated range.
By their numbers in this assay, from the lowest: compound 2; then compounds 4, 3 and 1 (each within the scatter of the next).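

In this assay, a carbon-only ring at this position did not by itself bring a lower number: there is a 1.2-fold lower number from compound 3 to compound 4 (0.07 log units; within the scatter), and a 1.3-fold lower number from compound 1 to compound 4 (0.11 log units; within the scatter), so 3-methylphenyl sits level with both heteroaromatic rings. Among the four compounds, only the 4-methoxyphenyl ring stands apart, with an 8.1-fold higher number from compound 2 to compound 4 (0.91 log units; beyond the scatter). Nothing measured here explains this difference.

The compounds shown leave open whether the methoxy group itself sets compound 2 apart, and how a phenyl ring carrying an amine or a longer alkoxy chain would read at this position.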